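Cytotoxicity notes on the shared core: compound 1 to compound 4

This account rests on a few compounds, and the source may have more. Where it says the series, first, only, none or still open, it means among the compounds named here.

Measured so far in an ADME assay on Vero cells (Chlorocebus sabaeus) for cytotoxicity; on this read-out higher numbers stand for lower toxicity in this test and lower numbers for higher toxicity in this test:
compound 1 `Fc1ccc(-c2nn3c(NC4CCCC4)cccc3c2-c2ccsc2)cc1`: "not determined" (no result reported)
compound 2 `Fc1ccc(-c2nn3c(NC4CCCC4)cccc3c2-c2ccnnc2)cc1`: "not determined" (no result reported)
compound 3 `Fc1ccc(-c2nn3c(NC4CCCC4)cccc3c2-c2ccncc2)cc1`: 20000 nM

Compound 1 stands without a number in this assay, and compound 2 likewise; the only figure in the set belongs to compound 3, which gives 20000 nM in this assay. Among the compounds with values here, no step between two measured compounds exists, so no size of step is known from the data.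

The change is 2-aminopyrimidin-4-yl in place of thiophen-3-yl on an aromatic carbon, giving compound 4 `Nc1nccc(-c2c(-c3ccc(F)cc3)nn3c(NC4CCCC4)cccc23)n1`. Within the data shown here, with no measured step to lean on, the expectation for compound 4 in this assay rests only on compound 3, whose value 20000 nM is the sole anchor; no shift beyond the scatter is assumed in either direction. Compound 4 is estimated at 20000 nM, in the range 7000 nM to 50000 nM.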

Compound 4, half-maximal cytotoxic concentration: 46000 nM
Compound 4: the middle estimate sits 2.3-fold (0.36 log units) below what was measured; the range from low to high includes it.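

In this assay, within the data shown here, 2-aminopyrimidin-4-yl in place of pyridin-4-yl on this aromatic carbon gives a 2.3-fold higher number from compound 3 to compound 4 (0.36 log units; beyond the scatter) as the only readable step at this position. The step is modest but beyond the scatter, and it runs toward lower toxicity in this test. Nothing at hand explains this shift.

Steps involving compound 1 and compound 2 cannot be read, as neither has a number. On these data alone, how a pyrimidin-4-yl without the amine, or a carboxylic acid, on this carbon would read in this assay remains open.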